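The compounds below may be only part of what the source reports. "The series", "measured", "known", "first", "only" and "open" are said of these compounds alone.

Compound 1 `CC(C)c1ccccc1NC(=O)N[C@H](C)c1ccccc1`: 101%
Compound 2 `CC(C)c1ccccc1NC(=O)N[C@@H](C)c1ccccc1`: 96%
Compound 3 `C[C@H](NC(=O)Nc1cccc(C(F)(F)F)c1)c1ccccc1`: 93%

All three numbers come from an ADME assay on the whole organism with Oryza sativa as the target, tested at 1 uM; on this read-out lower numbers stand for a stronger effect and higher numbers for a weaker effect at the one concentration tested. Compound 2 gives 96% in this assay, a number that lies between the ones for compound 1 and compound 3; the gap to compound 3 and the gap to compound 1 both stay within the usual scatter, so the three compounds cannot be told apart on these figures.

Compound 4 `COc1ccccc1NC(=O)N[C@@H](C)c1ccccc1` is not yet measured. It differs from compound 2 in one place: methoxy in place of isopropyl on an aromatic carbon. Among the compounds with values here, the only measured step, a number 5 percentage points lower from compound 1 to compound 2 (within the scatter), concerns the configuration at the saturated chain carbon the fact that compounds 1 and 2 differ only in the configuration as drawn and not the group on the aromatic ring, so it does not bear on this change. Within the data shown here, compounds 2 and 3 carry different groups on that ring and give numbers within the scatter of each other, which is the closest hint on hand, though no single step links them.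

Among the measured compounds shown here, with no measured step pointing to a shift, compound 4 is expected to give 95% in this assay, somewhere between 80% and 106%, so the estimated step of a number 1 percentage points lower from compound 2 to compound 4 (within the scatter) is not expected to go beyond the scatter.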

Compound 4, a percentage reported as activity, at one concentration (the size of the read-out at that concentration, not a potency): 99%
Beside the measured number, compound 4's estimate is 4 percentage points below it, within the range that was stated.
By their numbers in this assay, from the lowest: compounds 3, 2, 4 and 1 (each within the scatter of the next).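

Within the data shown here, this comparison is the first one that changes the group at this ring position, since the only earlier step concerned the configuration at the chain carbon. In this assay, putting methoxy in place of isopropyl on an aromatic carbon, ortho to a large group, gives a number 3 percentage points higher from compound 2 to compound 4 (within the scatter), so replacing an all-carbon group with a smaller one that brings in a hydrogen-bond acceptor does not produce a change that can be told from the scatter at the single concentration tested. Nothing on hand bears on why the number stays within the scatter for this change.

Going by these compounds, it remains open whether a quite different group at this position, such as an amine or a carboxylic acid, would give a number that stands clear of the scatter. Among these compounds, also open is whether methoxy would behave the same way with the opposite configuration at the chain carbon, the one drawn in compound 1, and, as the read-out comes from one concentration, how these compounds would compare across a range of concentrations.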